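This account rests on a few compounds, and the source may have more. Where it says the series, first, only, none or still open, it means among the compounds named here.

Measured so far in a physicochemical assay for solubility, read by chemiluminescence, in phosphate buffer, measured as kinetic solubility, at pH 7.4; on this read-out lower numbers stand for lower solubility and higher numbers for higher solubility:
- compound 1 `Cn1ccc(Nc2ccc(C(=O)NCC3(c4nc(-c5ccccc5)cs4)CCOCC3)cc2)n1`: 48000 nM
- compound 2 `O=C(NCC1(c2nc(-c3ccccc3)cs2)CCOCC1)c1ccc(Nc2nncs2)cc1`: 29000 nM

Compound 1 stands at the highest of the two numbers in this assay, but its nearest neighbour compound 2 lies close: the step of a 1.7-fold lower number from compound 1 to compound 2 (0.22 log units; within the scatter) is within the scatter, so no order between the two is established. Compound 3 `O=C(NCC1(c2nc(-c3ccccc3)cs2)CCOCC1)c1ccc(-c2cnco2)cc1` is still to be measured. It departs from compound 1 as follows: 1,3-oxazol-5-yl in place of (1-methyl-1H-pyrazol-3-yl)amino on an aromatic carbon. For the measured compounds named here, no measured step bears directly on this change. Going by the values given here, the one step available, from compound 1 to compound 2, swaps a substituent on a nitrogen on an aromatic ring and leaves the amino linkage in place, whereas here the whole (1-methyl-1H-pyrazol-3-yl)amino group is removed and 1,3-oxazol-5-yl enters on the aromatic carbon. With only a within-scatter step to draw on, no shift beyond the scatter can be argued for; a small movement toward lower solubility is taken as the estimate, with a wide range. The value of compound 3 in this assay is expected at 25000 nM, between 8000 nM and 70000 nM, corresponding to an expected step of a 1.9-fold lower number from compound 1 to compound 3 (0.28 log units; within the scatter).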

Compound 3, solubility: 71000 nM
For compound 3 the middle estimate is 2.8-fold (0.45 log units) below the measured one; the measured number lies above the stated range.
By their numbers in this assay, from the lowest: compounds 2, 1 and 3 (each within the scatter of the next, the first and the last beyond it).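

At the aromatic carbon para to a large group, the whole (1-methyl-1H-pyrazol-3-yl)amino group can give way to 1,3-oxazol-5-yl, with the amino linkage gone, and this assay still shows only a 1.5-fold higher number from compound 1 to compound 3 (0.17 log units; within the scatter), so no order between these two is established. Against the (1,3,4-thiadiazol-2-yl)amino group the same ring gives a 2.4-fold higher number from compound 2 to compound 3 (0.39 log units; beyond the scatter), the only step shown that passes the scatter, and compound 1 keeps this from being a general separation of amino-linked from directly attached rings. No supporting measurement accounts for either step.

The compounds shown leave open whether these steps follow the amino linkage or the ring it carries, as the two change together in both. Open too, on these data alone, is where this assay would place a morpholine or a carboxylic acid on that aromatic carbon.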